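The source may hold more compounds than are shown below. What is called first, only, known or untested is meant among the compounds shown, and "the series" means these compounds.

Measured compounds:
- compound 1, `NC1=NC2(CCSCC2)N(OCCCOc2cccc(Cl)c2)C(N)=N1`: 88.3%
- compound 2, `NC1=NC2(CCOCC2)N(OCCCOc2ccc(F)cc2)C(N)=N1`: > 90%

In an assay on isolated protein for inhibition of Dihydrofolate reductase (Homo sapiens), read by spectrophotometry, using NADPH, with stated times of 5 s and 6 min, tested at 5 uM (on this read-out higher numbers stand for a stronger effect at the one concentration tested and lower numbers for a weaker effect), compound 1 gives 88.3%. For compound 2 the read-out in this assay is reported only as a limit of the assay, > 90%. This reading sits at the limit of > 90% in this assay, at which 1 of the 2 values shown sits, so compound 2 has no number of its own on the scale, only a limit, and its standing relative to compound 1 cannot be read as a difference beyond the scatter.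

Compound 3, `NC1=NC2(CCOCC2)N(OCCCOc2ccc(Cl)cc2)C(N)=N1`, has not yet been measured. Compared with compound 2 it carries chloro in place of fluoro on an aromatic carbon. For the measured compounds named here, no measured pair differs in this single place, so the size of the step cannot be read from the data. Besides other differences from compound 2, a chloro group on the aromatic ring is also carried by compound 1, and compound 1 gives 88.3%. In this assay the expected step is a number no higher from compound 2 to compound 3 (the limit leaves the size open), none beyond the scatter. Compound 3 is expected to give 90%, between 80% and 96%, with a fair chance that only a limit is reported again.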

Compound 3, a percentage reported as inhibition, at one concentration (the size of the read-out at that concentration, not a potency): > 90%
Compound 3: no number, only a limit (the forecaster's own chance of this, stated with the estimate: 55%); the middle value lies on the limit itself.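

For the compounds shown here, compound 2 and compound 3 are both reported only as limits in this assay, so no step between them can be read: the limit of > 90% in this assay, at which 2 of the 3 values shown sit.
The compounds shown leave open whether chloro in place of fluoro on the aromatic ring changes the read-out in this assay at all, and by how much.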